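A few compounds are considered here, and "the series" means these few. Any claim that something is new, unique, unknown or untested is made for them only; others in the source may bear on it.

Compound 1 `CC(OC(=O)Nc1c(-c2ccc(F)cc2)cnn1C)c1ccccc1Cl`: in an in vitro functional assay on chem-1 cells for antagonist activity at lysophosphatidic acid receptor 3 (Homo sapiens), read by FLIPR and calcium flux, with stated times of 30 min and 100 s (a higher number here means a weaker inhibitor, a lower number a stronger inhibitor), compound 1 gives only a limit, > 30000 nM.
Compound 2 `C[C@@H](OC(=O)Nc1c(-c2ccc(-c3ccc(CC(=O)O)cc3)cc2)nnn1C)c1ccccc1`: in this assay compound 2 gives 21900 nM.

For the measured compounds named here, compound 2 stands as the only numerical value shown; the other value, that of compound 1, is a limit, as the limit of > 30000 nM in this assay, at which 1 of the 2 values shown sits, records. Going by the values given here, no step between measured compounds is recorded, so the two values show only that compound 2 gives a number where compound 1 does not.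

Compound 3 `C[C@@H](OC(=O)Nc1c(-c2ccc(-c3ccc(C4(C(=O)NS(C)(=O)=O)CC4)cc3)cc2)nnn1C)c1ccccc1` differs from compound 2 by a group of 10 heavy atoms (5 carbon, 1 nitrogen, 3 oxygen, 1 sulfur; one three-membered non-aromatic ring of carbon only) in place of a group of 4 heavy atoms (2 carbon, 2 oxygen; no ring), on an aromatic carbon, in words a group of 10 heavy atoms (5 carbon, 1 nitrogen, 3 oxygen, 1 sulfur; one three-membered non-aromatic ring of carbon only) in place of a group of 4 heavy atoms (2 carbon, 2 oxygen; no ring), on an aromatic carbon. Among the compounds with values here, with no measured step to rest on, the expected step in this assay is a modest one toward a stronger inhibitor, barely beyond the scatter. Compound 3 is therefore expected at 9000 nM, with a range from 2500 nM to 30000 nM. The step this estimate means is a 2.4-fold lower number from compound 2 to compound 3 (0.39 log units; beyond the scatter).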

Compound 3, half-maximal inhibitory concentration: 2310 nM
Compound 3: the middle estimate sits 3.9-fold (0.59 log units) above what was measured; measured number outside the range, below it.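

The change at this position, on an aromatic carbon para to a large group, now has a size: putting the larger group with its three-membered carbon ring in place of carboxymethyl gives a 9.5-fold lower number from compound 2 to compound 3 (0.98 log units; beyond the scatter) in this assay. This shows that the number moves clearly with what stands at this one place while the rest of the structure stays the same, even though both groups count 1 hydrogen-bond donor and neither carries a net charge. Nothing given here bears on why the step arises.

The compounds shown leave open whether the three-membered ring or the rest of the entering group carries the step. They also leave open how this position would read with a tetrazole or a primary amide in that place.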